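Amide substituent change from compound 2 to compound 3

A few compounds are considered here, and "the series" means these few. Any claim that something is new, unique, unknown or untested is made for them only; others in the source may bear on it.

Within the data shown here, compound 2 `Cc1ccccc1N/C(=N\C#N)NC(NC(=O)CCCc1ccccc1)C(C)(C)C` gives 25.1 nM in a functional assay on HEK293 cells for antagonist activity at P2X purinoceptor 7 (Rattus norvegicus), read by FLIPR and calcium flux (a lower number here means a stronger inhibitor, a higher number a weaker inhibitor), the lowest of the two numbers so far, while compound 1 `COc1ccc(CCC(=O)NC(N/C(=N/C#N)Nc2ccccc2C)C(C)(C)C)cc1OC` gives 316 nM in this assay. Among the measured compounds shown here, the only measured step, a 13-fold lower number from compound 1 to compound 2 (1.10 log units; beyond the scatter), is large. Compound 3 `COc1ccc(C(=O)NC(N/C(=N/C#N)Nc2ccccc2C)C(C)(C)C)cc1OC` differs from compound 2 by 3,4-dimethoxyphenyl in place of 3-phenylpropyl on a carbonyl carbon. That step bears on the change here, since the 3,4-dimethoxyphenyl group returns, although the loss of the chain is not covered by any measured pair. A weakening step is therefore expected, a 12-fold higher number from compound 2 to compound 3 (1.08 log units; beyond the scatter). Compound 3 is estimated at 300 nM, with a range from 80 nM to 1500 nM.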

Compound 3, half-maximal inhibitory concentration: 631 nM
Estimate against measurement, compound 3: 2.1-fold (0.32 log units) below; low and high end bracket the measured number.
By their numbers in this assay, from the lowest: compound 2; then compounds 1 and 3 (each within the scatter of the next).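

In this assay the replacement of 3-phenylpropyl by 3,4-dimethoxyphenyl on the carbonyl carbon gives a 25-fold higher number from compound 2 to compound 3 (1.40 log units; beyond the scatter) and so is a second large weakening step from compound 2. Compound 1 and compound 3, which both carry 3,4-dimethoxyphenyl, lie within the scatter of each other, so the saturated chain of compound 1 gives no separable gain on these numbers. Nothing measured on these compounds accounts for either step.

Still open, as far as these compounds go, is whether the ring substituents or the chain matter more for the low number of compound 2. A plain phenyl directly on the carbonyl carbon and a 3-(3,4-dimethoxyphenyl)propyl group would separate the two.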